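Compound 2 to compound 4: exchange on the amide nitrogen

The source may hold more compounds than are shown below. What is called first, only, known or untested is meant among the compounds shown, and "the series" means these compounds.

In a functional assay on HL-60 cells (Homo sapiens), with a stated time of 2 days (on this read-out lower numbers stand for stronger inhibition and higher numbers for weaker inhibition), compound 2 `C[C@H](NC(=O)c1[nH]cnc1C(=O)Nc1ccc(Cl)c(Cl)c1)c1ccccc1` gives 9200 nM. Compound 3 `COC(=O)[C@H](NC(=O)c1[nH]cnc1C(=O)Nc1ccc(Cl)c(Cl)c1)c1ccccc1` gives 17300 nM, and a 1.9-fold higher number from compound 2 to compound 3 (0.27 log units; within the scatter) leaves these two unseparated. Compound 1 `O=C(NC1CCCCC1)c1nc[nH]c1C(=O)Nc1ccc(Cl)c(Cl)c1` gives 33100 nM, a gap beyond the scatter from compound 2.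

Compound 4 `COC(=O)[C@@H](NC(=O)c1[nH]cnc1C(=O)Nc1ccc(Cl)c(Cl)c1)C(C)C` is the next to be read. Its difference is 1-(methoxycarbonyl)-2-methylpropyl in place of 1-phenylethyl on an amide-type nitrogen.

Two measurements bear on this. The measured step of a 1.9-fold higher number from compound 2 to compound 3 (0.27 log units; within the scatter) introduces methoxycarbonyl but keeps the aromatic ring, so it covers only part of the change. Compound 1, whose group on that nitrogen also lacks an aromatic ring, stands at 33100 nM, though it differs from compound 4 in other ways. Going by the values given here, no measured step isolates loss of the ring. A modest rise in this assay is therefore expected, with an estimated 2.2-fold higher number from compound 2 to compound 4 (0.34 log units; beyond the scatter). For compound 4 the estimated value is 20000 nM, with an expected range of 9000 nM to 45000 nM.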

Compound 4, half-maximal inhibitory concentration: > 62500 nM
Compound 4: no number, only a limit (the forecaster's own chance of this, stated with the estimate: 10%); middle value at least 3.1-fold (0.49 log units) away from the limit.
By their numbers in this assay, from the lowest: compounds 2, 3 and 1 (each within the scatter of the next, the first and the last beyond it). At a limit, above all of these: compound 4.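

In this assay compound 4 gives > 62500 nM, which is a limit of the assay and not a number: the limit of > 62500 nM in this assay, at which 1 of the 4 values shown sits.

The full exchange on the amide-type nitrogen is a clear step, an at least 6.7-fold higher number from compound 2 to compound 4 (0.83 log units; beyond the scatter), whereas methoxycarbonyl in place of methyl with the aromatic ring kept gives only a 1.9-fold higher number from compound 2 to compound 3 (0.27 log units; within the scatter). Methoxycarbonyl alone therefore does not account for the rise at this position, which appears only when the aromatic ring is also gone and the 2-methylpropyl chain has entered.

Compound 4 changes these features together, so the share of losing the ring and the share of the branched chain cannot be separated. As far as these compounds go, how a benzyl group, or a carboxylic acid in place of the methyl ester, would read on this nitrogen substituent stays open.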